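Working notes: amide aryl swap in a chromene ester series

A few compounds are considered here, and "the series" means these few. Any claim that something is new, unique, unknown or untested is made for them only; others in the source may bear on it.

Measured compounds in a functional assay on A549 cells (Homo sapiens) for inhibition, read by MTT assay, with a stated time of 24 h; a lower number here means a stronger inhibitor, a higher number a weaker inhibitor:
compound 1 `CCOC(=O)C1=Cc2ccccc2OC1(OCc1cn(-c2ccc(F)cc2)nn1)C(F)(F)F`, 7300 nM
compound 2 `CCOC(=O)C1=Cc2ccccc2OC1(OCc1cn(CC(=O)Nc2ccc(C)cc2)nn1)C(F)(F)F`, 54300 nM
compound 3 `Cc1ccc(-c2cc(COC3(C(F)(F)F)Oc4ccccc4C=C3C(=O)O)on2)cc1`, 51200 nM

Compound 2 gives the highest number of the three in this assay. Its nearest neighbour is compound 3, whose value sits within the scatter of that of compound 2, so no order between these two can be claimed. Among the compounds with values here, compound 1 is the only one that stands apart: the single counted step, a 7.4-fold higher number from compound 1 to compound 2 (0.87 log units; beyond the scatter), is beyond the scatter and is the sole measured step in the set.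

The next compound, compound 4 `CCOC(=O)C1=Cc2ccccc2OC1(OCc1cn(CC(=O)Nc2ccccc2Br)nn1)C(F)(F)F`, differs from compound 2 in one place: 2-bromophenyl in place of 4-methylphenyl on an amide-type nitrogen. Within the data shown here, no measured step touches this position. Among the measured compounds shown here, the one known step, from compound 1 to compound 2, changes the substituent on the aromatic nitrogen of the triazole, not the aryl on the amide nitrogen, so it gives no direct reading on the present change. Compound 2 and compound 3, both carrying a 4-methylphenyl, sit together within the scatter, which says nothing about a 2-bromophenyl either.

For the measured compounds named here, with no bearing step, the expected change from compound 2 to compound 4 in this assay is a 1.1-fold lower number from compound 2 to compound 4 (0.04 log units; within the scatter), none beyond the scatter. Compound 4 is therefore estimated at 50000 nM, with a range from 18000 nM to 140000 nM.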

Compound 4, half-maximal inhibitory concentration: > 150000 nM
Compound 4: only a limit was reported; the forecaster's own chance of this, stated with the estimate: 15%; at least 3.0-fold (0.47 log units) between middle value and limit.
By their numbers in this assay, from the lowest: compound 1; then compounds 3 and 2 (each within the scatter of the next). At a limit, above all of these: compound 4.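

In this assay compound 4 carries a limit of the assay, not a number: the limit of > 150000 nM in this assay, at which 1 of the 4 values shown sits. Within the data shown here, this is the first reading at the aryl on the amide-type nitrogen, and it shows that this position is not indifferent: 2-bromophenyl in place of 4-methylphenyl gives an at least 2.7-fold higher number from compound 2 to compound 4 (0.44 log units; beyond the scatter), a step that rests on a limit and so has no upper bound on its size. With ((2-bromophenyl)carbamoyl)methyl in place of 4-fluorophenyl on an aromatic nitrogen, the result is an at least 20-fold higher number from compound 1 to compound 4 (1.31 log units; beyond the scatter), which goes further than the step printed for ((4-methylphenyl)carbamoyl)methyl at that same place, a 7.4-fold higher number from compound 1 to compound 2 (0.87 log units; beyond the scatter).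

The two amide aryl groups differ both in the substituent and in where it stands, so the compounds shown cannot separate the bromine from its location; 4-bromophenyl and 2-methylphenyl on the same nitrogen would pull these two apart. As far as these compounds go, how an unsubstituted phenyl, or an aryl carrying an amine or a carboxylic acid, would read at this position also remains open.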